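The source may hold more compounds than are shown below. What is called first, only, known or untested is meant among the compounds shown, and "the series" means these compounds.

Three compounds sharing one core differ only in the aromatic ring on an amide-type nitrogen. In a functional assay on NCI-H1299 cells (Homo sapiens) for inhibition, read by CCK-8 assay, with a stated time of 72 h, tested at 1 uM (a lower number here means less inhibition of growth, a higher number more inhibition of growth at the concentration tested), compound 1 `CN(C)C(=O)c1cc2cnc(Nc3ccc(NC(=O)C4(C(=O)Nc5cccc(F)c5)CC4)cc3)nc2n1C1CCCC1`, with 3-fluorophenyl, gives 64.2%. Compound 2 `CN(C)C(=O)c1cc2cnc(Nc3ccc(NC(=O)C4(C(=O)Nc5ccc(Br)cc5)CC4)cc3)nc2n1C1CCCC1`, with 4-bromophenyl, gives 27.6%, and compound 3 `CN(C)C(=O)c1cc2cnc(Nc3ccc(NC(=O)C4(C(=O)Nc5ccc(O)cc5)CC4)cc3)nc2n1C1CCCC1`, with 4-hydroxyphenyl, gives 87.4%, the highest of the three numbers.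

The next compound, compound 4 `CN(C)C(=O)c1cc2cnc(Nc3ccc(NC(=O)C4(C(=O)Nc5ccccc5)CC4)cc3)nc2n1C1CCCC1`, puts hydrogen in place of hydroxy on an aromatic carbon of compound 3, leaving plain phenyl: hydrogen in place of hydroxy on an aromatic carbon.

Within the data shown here, three measured steps bear on this change. The closest is a number 59.8 percentage points higher from compound 2 to compound 3 (beyond the scatter), a large step at this same carbon. The others are a number 23.2 percentage points higher from compound 1 to compound 3 (beyond the scatter), a modest step, and a number 36.6 percentage points lower from compound 1 to compound 2 (beyond the scatter), a large one. Both compounds without the hydroxy lie lower than compound 3, yet they lie far apart, so this ring clearly matters but the outcome for plain phenyl stays uncertain.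

A modest to large drop is expected, estimated as a number 27.4 percentage points lower from compound 3 to compound 4 (beyond the scatter). For compound 4 the expected value is 60%, with an estimated range from 35% to 82%.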

Compound 4, percent growth inhibition at one concentration: 71.2%
Beside the measured number, compound 4's estimate is 11.2 percentage points below it; low and high end bracket the measured number.
By their numbers in this assay, from the lowest: compound 2; then compounds 1 and 4 (each within the scatter of the next); then compound 3.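

Plain phenyl gives this ring a reference point in (this assay): compound 4 keeps much of the growth inhibition without the hydroxy, so the 4-hydroxyphenyl group adds to the effect but is not required for it (a number 16.2 percentage points lower from compound 3 to compound 4 (beyond the scatter)). The bromo compound is the one that stands apart, since replacing bromo with hydrogen gives the largest new step (a number 43.6 percentage points higher from compound 2 to compound 4 (beyond the scatter)), whereas the fluoro compound and plain phenyl cannot be told apart (a number 7 percentage points higher from compound 1 to compound 4 (within the scatter)). Nothing shown here explains why these groups rank as they do.

Fluoro and bromo also sit at different places on the ring, so the identity of the halogen cannot be separated from its position. From the compounds shown here alone, whether an amino group, a methoxy group or a carboxylic acid on the same carbon would match the hydroxy remains open.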